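From isopentyl to cyclopropyl on an aromatic nitrogen

This account rests on a few compounds, and the source may have more. Where it says the series, first, only, none or still open, it means among the compounds named here.

Compound 1 `Cn1sc2cc(OCc3cccc(-c4ccc(Cl)c(C(=O)O)c4)c3)ccc2c1=O`: 84%
Compound 2 `CC(C)CCn1sc2cc(OCc3cccc(-c4ccc(Cl)c(C(=O)O)c4)c3)ccc2c1=O`: 92%

In an ADME assay on microsomes from liver (Rattus norvegicus) for metabolic stability, read by LC-MS, with a stated time of 1 h, at 37 degrees C, tested at 4 uM (on this read-out higher numbers stand for a more stable compound and lower numbers for a less stable compound), compound 2 gives 92%, which lies within the scatter of compound 1 at 84%. Compound 3 `O=C(O)c1cc(-c2cccc(COc3ccc4c(=O)n(C5CC5)sc4c3)c2)ccc1Cl` differs from compound 2 in one place, with cyclopropyl in place of isopentyl on an aromatic nitrogen.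

Going by the values given here, only one measured step bears on this change: a number 8 percentage points higher from compound 1 to compound 2 (within the scatter). That step also concerns the group carried on the aromatic nitrogen, and it stayed within the scatter. It is thin evidence, however. Neither compound 1 nor compound 2 carries a ring at this place, so the data do not test cyclopropyl directly. Among the compounds with values here, with the single step of a number 8 percentage points higher from compound 1 to compound 2 (within the scatter) as the guide, no step beyond the scatter is expected in this assay, and no firm direction can be given. The expected step is a number 6 percentage points lower from compound 2 to compound 3 (within the scatter), which would lie within the scatter. For compound 3 the estimated value is 86%, with an expected range of 73% to 96%.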

Compound 3, percent of the compound remaining: 86%
Estimate against measurement, compound 3: no gap at the digits printed; the range from low to high includes it.
By their numbers in this assay, from the lowest: compounds 1, 3 and 2 (each within the scatter of the next).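

Going by these compounds alone, with cyclopropyl, a ring stands for the first time on the aromatic nitrogen, and in this assay the exchange for isopentyl gives a number 6 percentage points lower from compound 2 to compound 3 (within the scatter), while the exchange for methyl gives a number 2 percentage points higher from compound 1 to compound 3 (within the scatter). The three compounds therefore cannot be told apart in this read-out: methyl, isopentyl and cyclopropyl all sit within the scatter of one another, so a small ring at this place reads no differently from a short or a longer open chain. No measurement at hand says why these groups read alike.

The compounds shown leave open whether this flat picture holds for groups of another kind on the same nitrogen, such as an amine-bearing chain, a hydroxyethyl chain or a phenyl ring, since each group here consists of carbon alone. They also leave open whether a larger ring, such as cyclohexyl, would stay within the same band, and whether the same would be seen if the carboxylic acid or the chlorine elsewhere on the shared core were replaced.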